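The compounds below may be only part of what the source reports. "The series", "measured", "known", "first", "only" and "open" are said of these compounds alone.

Compound 1 `COc1cc(N2C(N)=C(C#N)C(c3c(O)ccc4ccccc34)C3=C2CC(C)(C)CC3=O)cc(OC)c1OC` and compound 2 `COc1cc(N2C(N)=C(C#N)C(c3ccccc3Cl)C3=C2CC(C)(C)CC3=O)cc(OC)c1OC` share one core and differ only at a saturated ring carbon. In a functional assay on Ehrlich cells (Mus musculus) for cytotoxicity, tested at 10 ug/mL (on this read-out higher numbers stand for a stronger effect at the one concentration tested and lower numbers for a weaker effect), compound 1 gives 2% and compound 2 gives 10%; the step of a number 8 percentage points higher from compound 1 to compound 2 (within the scatter) separates them, so compound 2 stands at the higher of the two numbers without being separable from compound 1. Compound 3 `COc1cc(N2C(N)=C(C#N)C(c3ccc(C)o3)C3=C2CC(C)(C)CC3=O)cc(OC)c1OC` carries the change (5-methylfuran-2-yl in place of 2-chlorophenyl on a saturated ring carbon). Within the data shown here, the only measured step at this position stayed within the scatter, and no measured step involves this group, so no shift beyond the scatter is expected; the step of a number 2 percentage points lower from compound 2 to compound 3 (within the scatter) is the estimate, giving compound 3 an expected 8% with a range from 0% to 22%.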

Compound 3, a percentage reported as activity, at one concentration (the size of the read-out at that concentration, not a potency): 21%
Compound 3: the middle estimate sits 13 percentage points below what was measured; measured number inside the range.
By their numbers in this assay, from the lowest: compounds 1 and 2 (each within the scatter of the next); then compound 3.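

This position is not silent: in this assay the change to 5-methylfuran-2-yl gives a number 11 percentage points higher from compound 2 to compound 3 (beyond the scatter) and a number 19 percentage points higher from compound 1 to compound 3 (beyond the scatter). Both steps are modest, yet they separate compound 3 from two aromatic groups that could not be separated from each other. The five-membered aromatic ring with one hetero atom therefore gives the strongest effect of these three compounds at the one concentration tested.

Open, as far as these compounds go, is whether the methyl group on that ring contributes, and how an amine or a carboxylic acid on the ring would read. Nothing on hand accounts for the rise.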